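A few compounds are considered here, and "the series" means these few. Any claim that something is new, unique, unknown or untested is made for them only; others in the source may bear on it.

Working notes on the series.

Compound 1 `COc1cc(OC)c2c(=O)cc(-c3ccc(OC4CCN(C)CC4)cc3)oc2c1` is the reference point. In a functional assay (Homo sapiens) for antiproliferative activity, read by resazurin assay, with a stated time of 48 h, tested at 5 uM (a higher number here means a stronger effect of the compound at the concentration tested, a lower number a weaker effect), compound 1 gives 28%, which is the lower of the two numbers available in this set. Compound 2 `COc1cc(OC)c2c(=O)cc(-c3ccc(OCCCN(C)C)cc3)oc2c1` gives 36% in this assay, and the step of a number 8 percentage points higher from compound 1 to compound 2 (within the scatter) lies within the scatter, so the two are not separable. Compound 3 `COc1cc(OC)c2c(=O)cc(-c3ccc(OC4CCNCC4)cc3)oc2c1` is recorded in this assay as "not active" (no number reported), with no number attached.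

Compound 4 `COc1cc(OC)c2c(=O)cc(-c3ccc(NCCN(C)C)cc3)oc2c1` has not been measured. It differs from compound 1 as follows: (2-(dimethylamino)ethyl)amino in place of (1-methylpiperidin-4-yl)oxy on an aromatic carbon. For the measured compounds named here, no measured step matches this change. Going by the values given here, the one comparison that bears on it is the step from compound 1 to compound 2, which replaced the ring group on the oxygen with an open chain carrying a dimethylamino end and stayed within the scatter. Compound 3, with its unmethylated ring nitrogen, gave no number. On this basis compound 4 is expected to stay close to compound 1, with a step of a number 2 percentage points higher from compound 1 to compound 4 (within the scatter) that does not reach beyond the scatter. The estimate for compound 4 in this assay is 30%, with a range from 10% to 50%.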

Compound 4, a percentage reported as inhibition, at one concentration (the size of the read-out at that concentration, not a potency): 30%
Estimate against measurement, compound 4: no gap at the digits printed, and the stated range covers the measured number.
By their numbers in this assay, from the lowest: compounds 1, 4 and 2 (each within the scatter of the next).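

In this assay, the change to (2-(dimethylamino)ethyl)amino gives a number 2 percentage points higher from compound 1 to compound 4 (within the scatter) and a number 6 percentage points lower from compound 2 to compound 4 (within the scatter). At this position on the aromatic carbon, the read-out therefore does not separate an amino link carrying a hydrogen-bond donor from either oxygen-linked group, and an open chain of this size serves no differently from the ring group of compound 1 at the one concentration tested. No supporting data bear on why these three compounds are not separable.

Going by these compounds, whether a morpholine, a primary amine at the chain end or a longer chain on the amino nitrogen would move the number beyond the scatter remains open. The single-concentration read-outs also leave open any difference in potency among compounds 1, 2 and 4.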